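A few compounds are considered here, and "the series" means these few. Any claim that something is new, unique, unknown or untested is made for them only; others in the source may bear on it.

Compound 1 `COc1cc(-c2nn(-c3ccc(NC(=O)Nc4cccc(Cl)c4Cl)cc3)cc2-c2ccncc2)ccc1Cl` stands only at a limit on the numbers shown. In a functional assay on A375P cells (Homo sapiens) for antiproliferative activity, read by MTT assay, with a stated time of 48 h (a lower number here means a stronger inhibitor, a higher number a weaker inhibitor), compound 1 gives > 20000 nM, which is a limit of the assay and not a number. Compound 2 `COc1cc(-c2nn(-c3ccc(NC(=O)Nc4ccc(Cl)c(Cl)c4)cc3)cc2-c2ccncc2)ccc1Cl` is measured in this assay and gives > 20000 nM, again a limit. Compound 3 `COc1cc(-c2nn(-c3ccc(NC(=O)c4cc(Cl)cc(Cl)c4)cc3)cc2-c2ccncc2)ccc1Cl` in this assay gives > 20000 nM, also a limit. The measured steps a step that the two limits leave unreadable from compound 1 to compound 2, a step that the two limits leave unreadable from compound 1 to compound 3 and a step that the two limits leave unreadable from compound 2 to compound 3 therefore cannot be read in size or direction, because of the limit of > 20000 nM in this assay, at which 3 of the 3 values shown sit. Compound 4 `COc1cc(-c2nn(-c3ccc(NC(=O)c4ccc(Cl)c(C(F)(F)F)c4)cc3)cc2-c2ccncc2)ccc1Cl` differs from compound 1 in one place: 4-chloro-3-(trifluoromethyl)phenyl in place of (2,3-dichlorophenyl)amino on a carbonyl carbon. Of the three measured steps, those from compound 1 to compound 3 and from compound 2 to compound 3 bear most closely on this change, yet neither gives a readable size, so no step beyond the scatter can be expected from them, nor ruled out. Compound 4 is estimated to give about 15000 nM in this assay, with a range from 3000 nM to 40000 nM, and the expected step is an at least 1.3-fold lower number from compound 1 to compound 4 (0.12 log units; that floor lies within the scatter).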

Compound 4, half-maximal inhibitory concentration: 9800 nM
Compound 4: the middle estimate sits 1.5-fold (0.18 log units) above what was measured, within the range that was stated.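

Among these compounds, compound 4 is the first compound here to give a number rather than a limit in this assay, so a group on this carbonyl carbon can carry a readable value. The change reads as an at least 2.0-fold lower number from compound 1 to compound 4 (0.30 log units; that floor lies within the scatter), and the two comparisons with the other compounds read as an at least 2.0-fold lower number from compound 3 to compound 4 (0.30 log units; that floor lies within the scatter) and an at least 2.0-fold lower number from compound 2 to compound 4 (0.30 log units; that floor lies within the scatter). Each of these is only a floor within the scatter, and the true sizes stay unreadable because of where the other compounds sit: the limit of > 20000 nM in this assay, at which 3 of the 4 values shown sit.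

On these data alone, it stays open whether the 4-chloro-3-(trifluoromethyl)phenyl group would also give a number if joined through an amino link, as the dichlorophenyl groups of compound 1 and compound 2 are. Also open, as far as these compounds go, is what a nitrile or a carboxylic acid in place of the trifluoromethyl would give.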